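Cytotoxicity of Macrocyclic Acylsulfonamides: Swapping the Sulfonyl Group

A few compounds are considered here, and "the series" means these few. Any claim that something is new, unique, unknown or untested is made for them only; others in the source may bear on it.

Compound 1 `COc1ccc2c(OCC[C@@H]3NC(=O)N(C)CCCC/C=C\[C@@H]4C[C@@]4(C(=O)NS(=O)(=O)C4(C)CC4)NC3=O)cc(-c3nc(C(C)C)cs3)nc2c1F` — 57100 nM
Compound 2 `COc1ccc2c(OCC[C@@H]3NC(=O)N(C)CCCC/C=C\[C@@H]4C[C@@]4(C(=O)NS(=O)(=O)C4(F)CC4)NC3=O)cc(-c3nc(C(C)C)cs3)nc2c1Cl` — 51400 nM
Compound 3 `CCC1(S(=O)(=O)NC(=O)[C@@]23C[C@H]2/C=C\CCCCN(C)C(=O)N[C@@H](CCOc2cc(-c4nc(C(C)C)cs4)nc4c(Cl)c(OC)ccc24)C(=O)N3)CC1` — 49300 nM

These three compounds share one macrocyclic core and were tested in an ADME assay on cells (Homo sapiens) for activation; on this read-out lower numbers stand for higher toxicity in this test and higher numbers for lower toxicity in this test. Compound 2 gives the second highest of the three numbers, yet all three sit close together: the step of a 1.0-fold lower number from compound 2 to compound 3 (0.02 log units; within the scatter) is within the scatter, and compound 1 also lies within the scatter of compound 2. In other words, the three measured compounds are indistinguishable in this assay.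

Compound 4 `COc1ccc2c(OCC[C@@H]3NC(=O)N(C)CCCC/C=C\[C@@H]4C[C@@]4(C(=O)NS(=O)(=O)N4CCOCC4)NC3=O)cc(-c3nc(C(C)C)cs3)nc2c1Cl` is the next member. Compared with compound 2 it carries morpholin-4-yl in place of 1-fluorocyclopropyl on a sulfonyl sulfur. For the measured compounds named here, the one measured step that touches this part of the molecule, a 1.0-fold lower number from compound 2 to compound 3 (0.02 log units; within the scatter), exchanged one substituent on the small ring attached to the sulfonyl sulfur and moved nothing beyond the scatter. Going by the values given here, no measured step exchanges that ring itself for morpholin-4-yl, so the new change has no direct precedent here.

Given that every change seen so far left this assay flat, compound 4 is expected to behave like its neighbours, with an estimated step of a 1.0-fold lower number from compound 2 to compound 4 (0.01 log units; within the scatter). For compound 4 the estimated value is 50000 nM, within a range from 25000 nM to 100000 nM.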

Compound 4, half-maximal cytotoxic concentration: 26400 nM
Beside the measured number, compound 4's estimate is 1.9-fold (0.28 log units) above it; low and high end bracket the measured number.
By their numbers in this assay, from the lowest: compounds 4, 3, 2 and 1 (each within the scatter of the next, the first and the last beyond it).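

For the compounds shown here, compound 4 is the first case here where the whole group on the sulfonyl sulfur is exchanged, rather than one substituent on the small ring, and in this assay the result is a 1.9-fold lower number from compound 2 to compound 4 (0.29 log units; within the scatter). Measured against the 1-ethylcyclopropyl analogue, the same exchange gives a 1.9-fold lower number from compound 3 to compound 4 (0.27 log units; within the scatter), so both comparisons stay within the scatter, and this position accepts morpholin-4-yl, a six-membered ring containing nitrogen and oxygen, without a change that this test can distinguish from repeat-measurement noise. No supporting measurement is available to explain these values or to show what else the exchange altered.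

The compounds shown cover only cyclopropyl groups carrying a methyl, ethyl or fluoro substituent and one morpholin-4-yl group at this position, so it remains open whether a piperazin-1-yl ring, a dimethylamino group or a longer alkyl chain on the sulfonyl sulfur would also stay within the scatter. On these data alone, it also remains open whether morpholin-4-yl would give a similar result on the shared core with fluoro in place of chloro.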